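The source may hold more compounds than are shown below. What is called first, only, known or untested is meant among the compounds shown, and "the series" means these compounds.

Measured compounds in an assay on isolated protein for inhibition of DNA topoisomerase 1 (Homo sapiens), with a stated time of 30 min, tested at 100 uM; on this read-out higher numbers stand for a stronger effect at the one concentration tested and lower numbers for a weaker effect:
- compound 1 `Oc1ccc(-c2cc(-c3ccc(Cl)cc3)nc(-c3cccnc3)c2)cc1` gives 18.8%
- compound 2 `Oc1ccc(-c2cc(-c3ccncc3)nc(-c3cccc(Cl)c3)c2)cc1` gives 29.2%
- compound 3 `Oc1cccc(-c2cc(-c3ccncc3)nc(-c3ccc(Cl)cc3)c2)c1` gives 8%

Of the three, compound 3 stands lowest. Its nearest neighbour on the numbers is compound 1, which lies higher by a margin beyond the usual scatter; compound 2 lies higher still, also beyond the scatter. So compound 3 is the weakest of the three on this read-out.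

The next compound is compound 4 `Oc1ccc(-c2cc(-c3ccncc3)nc(-c3ccc(Cl)cc3)c2)cc1`. It differs from compound 3 in one place:
4-hydroxyphenyl in place of 3-hydroxyphenyl on an aromatic carbon
Compound 4 carries the same 4-hydroxyphenyl group that is present in compound 1 and compound 2, both of which sit above compound 3 in this assay. Among the measured compounds shown here, no step between two measured compounds that differ only at this spot is available, so the size of the change has to be read indirectly from where compound 1 and compound 2 stand. On that basis an upward step in this assay is expected, of moderate size, likely beyond the scatter but not large. The expected step is a number 13 percentage points higher from compound 3 to compound 4 (beyond the scatter). Compound 4 is therefore estimated at 21%, with a range from 9% to 34%.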

Compound 4, a percentage reported as inhibition, at one concentration (the size of the read-out at that concentration, not a potency): 5.9%
For compound 4 the middle estimate is 15.1 percentage points above the measured one; measured number below the stated range.
By their numbers in this assay, from the lowest: compounds 4 and 3 (each within the scatter of the next); then compound 1; then compound 2.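

In this assay, 4-hydroxyphenyl in place of 3-hydroxyphenyl on this aromatic carbon, opposite the ring nitrogen, gives a number 2.1 percentage points lower from compound 3 to compound 4 (within the scatter) and so does not shift the read-out measurably when 4-chlorophenyl and pyridin-4-yl are held fixed. Among the compounds shown here, the other two single changes leading to compound 4 do register: 4-chlorophenyl in place of 3-chlorophenyl gives a number 23.3 percentage points lower from compound 2 to compound 4 (beyond the scatter) and pyridin-4-yl in place of pyridin-3-yl gives a number 12.9 percentage points lower from compound 1 to compound 4 (beyond the scatter) in this series, so with 4-hydroxyphenyl held fixed, the placement on either of the other two rings counts for more than the hydroxyl placement does in the one pair available. Nothing available explains any of these steps.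

Whether the hydroxyl placement stays equally silent with 3-chlorophenyl or pyridin-3-yl on the core remains open, since the one pair shown carries only the 4-chlorophenyl and pyridin-4-yl groups. Also open, on these data alone, is how a methoxy group, an amine or a carboxylic acid in place of the hydroxyl would read at this position, and whether any of these single-concentration differences would carry over to potency.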